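The source may report more compounds than this note shows. Statements on the series, on what has been measured and on what is new or still open speak of the compounds shown alone.

Compound 1 `CC1CCN(C2CCN(S(=O)(=O)c3cccnc3Cl)CC2)CC1` has so far given only a limit: in a functional assay on DLD-1 cells (Homo sapiens) for antiproliferative activity, read by CellTiter-Glo, with a stated time of 72 h (on this read-out lower numbers stand for stronger inhibition and higher numbers for weaker inhibition), compound 1 gives > 5000 nM, which is a limit of the assay, not a number. Compound 2 `CC1CCCN(C2CCN(S(=O)(=O)c3ccc(OC(F)F)cc3)CC2)C1` carries a different core, and in this assay compound 2 gives 105 nM. Compound 3 `CC1CCN(C2CCN(S(=O)(=O)c3cccc(Br)c3)CC2)CC1` is compound 1 with 3-bromophenyl in place of 2-chloropyridin-3-yl on a sulfonyl sulfur. Going by the values given here, no measured pair shows what this exchange does, so the step is expected to run toward stronger inhibition, though only modestly. Compound 3 is estimated at 2500 nM, between 600 nM and 8000 nM, an expected step of an at least 2.0-fold lower number from compound 1 to compound 3 (0.30 log units; that floor lies within the scatter).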

Compound 3, half-maximal inhibitory concentration: 3.2 nM
Compound 3: the middle estimate sits 780-fold (2.89 log units) above what was measured; measured number below the stated range.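

On the sulfonyl sulfur, the choice of aromatic group matters greatly in this assay: 3-bromophenyl in place of 2-chloropyridin-3-yl gives an at least 1500-fold lower number from compound 1 to compound 3 (3.19 log units; beyond the scatter). Going by these compounds, compound 1 rests on a limit of the assay, so this step is only a floor and its true size is unknown: the limit of > 5000 nM in this assay, at which 1 of the 3 values shown sits. The exchange alters the ring nitrogen and the halogen together, so this one step cannot separate them.

Plain phenyl or chlorophenyl on the same sulfur would help to separate them, and their effect remains open. On these data alone, whether 3-bromophenyl would act similarly on the core of compound 2 also remains open.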